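Replacing Methyl with a Bromothiophene Sulfonyl Group

A few compounds are considered here, and "the series" means these few. Any claim that something is new, unique, unknown or untested is made for them only; others in the source may bear on it.

Measured compounds:
compound 1, `COc1ccc(-c2cc(=O)c3c(OC)cc(OC)cc3n2C)cc1`: 68000 nM
compound 2, `C=CCNC(=O)n1c(-c2ccc(OC)cc2)cc(=O)c2c(OC)cc(OC)cc21`: 74000 nM
compound 3, `COc1ccc(-c2cc(=O)c3c(OC)cc(OC)cc3n2S(=O)(=O)c2ccc(OC)cc2)cc1`: > 82700 nM (a limit)

Three compounds share one core and differ only in the group carried on an aromatic nitrogen. In an ADME assay on BJ cells (Homo sapiens) for antiproliferative activity, with a stated time of 72 h (on this read-out lower numbers stand for an effect already at smaller amounts and higher numbers for an effect only at larger amounts of compound), compound 1 gives 68000 nM, the lowest of the two plain numbers shown, though the gap to compound 2 is small. Compound 2 gives 74000 nM, and the step is a 1.1-fold higher number from compound 1 to compound 2 (0.04 log units; within the scatter). For compound 3 the assay reports only a limit, > 82700 nM.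

Compound 4, `COc1ccc(-c2cc(=O)c3c(OC)cc(OC)cc3n2S(=O)(=O)c2ccc(Br)s2)cc1`, is not yet measured. It differs from compound 1 in one place: (5-bromothiophen-2-yl)sulfonyl in place of methyl on an aromatic nitrogen. The nearest measured step is the similar sulfonyl swap, an at least 1.2-fold higher number from compound 1 to compound 3 (0.08 log units; that floor lies within the scatter), which ended at the limit; the step of an at least 1.1-fold higher number from compound 2 to compound 3 (0.04 log units; that floor lies within the scatter) points the same way. No change beyond the scatter has yet been seen among these three compounds. Compound 4 is therefore expected to show a 1.3-fold higher number from compound 1 to compound 4 (0.10 log units; within the scatter), with a fair chance that only a limit is reported. The estimate for compound 4 is 85000 nM, expected between 45000 nM and 170000 nM.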

Compound 4, half-maximal effective concentration: > 48200 nM
Compound 4 was reported as a limit (the forecaster's own chance of this, stated with the estimate: 50%); the middle value lies beyond the limit too.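

Compound 4 gives only a limit in this assay, > 48200 nM. Its steps from compound 1, compound 2 and compound 3 cannot be read. The compounds shown leave open whether any group on the aromatic nitrogen changes the number beyond the scatter, and how (5-bromothiophen-2-yl)sulfonyl compares with (4-methoxyphenyl)sulfonyl.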